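Shortening the Amine Side Chain from Isopropyl to Ethyl

The compounds below may be only part of what the source reports. "The series", "measured", "known", "first", "only" and "open" are said of these compounds alone.

Measured compounds:
- compound 1, `CCCNc1nnc(SCC(=O)N(Cc2cccc([N+](=O)[O-])c2)c2ccc(F)cc2)s1`, 12%
- compound 2, `CC(C)Nc1nnc(SCC(=O)N(Cc2cccc([N+](=O)[O-])c2)c2ccc(F)cc2)s1`, 10.8%

Both compounds were tested in an assay on isolated protein for inhibition of Amine oxidase [flavin-containing] A (Homo sapiens), read by fluorescence and Amplex Red, with a stated time of 30 min, tested at 0.1 nM; on this read-out higher numbers stand for a stronger effect at the one concentration tested and lower numbers for a weaker effect. Compound 1 gives 12% and compound 2 gives 10.8%. For the measured compounds named here, on these two numbers compound 2 stands lowest, but its only neighbour is compound 1, and the step of a number 1.2 percentage points lower from compound 1 to compound 2 (within the scatter) is within the scatter, so the two results cannot be told apart.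

Compound 3, `CCNc1nnc(SCC(=O)N(Cc2cccc([N+](=O)[O-])c2)c2ccc(F)cc2)s1`, has not yet been measured. It differs from compound 2 in one place: hydrogen in place of methyl on a saturated chain carbon bound to a nitrogen on an aromatic ring and a saturated chain carbon. Read one bond further out, this is isopropyl to ethyl on the amine of the shared core.

Going by the values given here, the only step that bears on this is the one from propyl to isopropyl on the same nitrogen, which changed nothing beyond the scatter. Removing one methyl from that side chain is a comparable small change, so no step beyond the scatter is expected in this assay in either direction.

Compound 3 is therefore estimated at 11%, within a range of 3% to 20%, an expected step of a number 0.2 percentage points higher from compound 2 to compound 3 (within the scatter).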

Compound 3, a percentage reported as inhibition, at one concentration (the size of the read-out at that concentration, not a potency): 14.2%
Beside the measured number, compound 3's estimate is 3.2 percentage points below it; the range from low to high includes it.
By their numbers in this assay, from the lowest: compounds 2, 1 and 3 (each within the scatter of the next).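

In this assay the isopropyl to ethyl change gives a number 3.4 percentage points higher from compound 2 to compound 3 (within the scatter) and the propyl to ethyl change gives a number 2.2 percentage points higher from compound 1 to compound 3 (within the scatter) on the same side chain. The amine of the shared core now carries three different small alkyl groups, straight or branched and of different lengths, and the read-out separates none of them, so neither shortening the chain nor removing the branch registers at this one concentration among these compounds. Nothing measured here offers an explanation of how these compounds read in this assay.

The compounds shown leave open whether any group on this nitrogen can move the read-out beyond the scatter, for example a longer chain such as butyl, a ring such as cyclohexyl, or a carboxylic acid at the end of the chain. As far as these compounds go, each figure is also a reading at a single concentration rather than a potency, so how these three compounds would compare at higher concentrations remains unknown.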